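A few compounds are considered here, and "the series" means these few. Any claim that something is new, unique, unknown or untested is made for them only; others in the source may bear on it.

Values so far in a functional assay on Ramos cells (Homo sapiens) for antiproliferative activity; on this read-out lower numbers stand for stronger inhibition and higher numbers for weaker inhibition
- compound 1 `Nc1ncnc2c1c(-c1ccc(NC(=O)c3ccccc3)cc1)cn2[C@H]1CCN(C[C@@H]2CO2)C1` gives 2250 nM
- compound 2 `CC(C)(C)c1ccc(COc2ccc(-c3cn([C@H]4CCN(C[C@@H]5CO5)C4)c4ncnc(N)c34)cc2)cc1` gives 4210 nM
- compound 3 `Nc1ncnc2c1c(-c1ccc(Oc3ccccc3)cc1)cn2C[C@H]1CCCN1C(CO)CO` gives 15300 nM

Compound 3 has the highest number of the three, and its gaps to compound 1 and compound 2 both lie beyond the scatter. Compound 4 `Nc1ncnc2c1c(-c1ccc(Oc3ccccc3)cc1)cn2[C@H]1CCN(C[C@@H]2CO2)C1` differs from it in one place, with 1-((oxiran-2-yl)methyl)pyrrolidin-3-yl in place of (1-(2-hydroxy-1-(hydroxymethyl)ethyl)pyrrolidin-2-yl)methyl on an aromatic nitrogen. Going by the values given here, no measured step isolates this change. Among the compounds with values here, the only measured step (a 1.9-fold higher number from compound 1 to compound 2 (0.27 log units; within the scatter)) lies within the scatter, and it replaces benzamido on an aromatic carbon while leaving the group on the nitrogen untouched. Compound 1 (2250 nM) and compound 2 (4210 nM) both carry the entering group, and compound 4 is therefore expected to sit near them, though neither shares the rest of its structure. The estimated step in this assay is towards a lower number and beyond the scatter (a 6.1-fold lower number from compound 3 to compound 4 (0.79 log units; beyond the scatter)). For compound 4 the estimate is 2500 nM (expected range 700 nM to 8000 nM).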

Compound 4, half-maximal inhibitory concentration: 6710 nM
The estimate for compound 4 lay 2.7-fold (0.43 log units) below the measured number; low and high end bracket the measured number.
By their numbers in this assay, from the lowest: compounds 1, 2 and 4 (each within the scatter of the next, the first and the last beyond it); then compound 3.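

In this assay, the group on the aromatic nitrogen now has a measured step of its own: with phenoxy on the aromatic carbon in both compounds, 1-((oxiran-2-yl)methyl)pyrrolidin-3-yl in place of (1-(2-hydroxy-1-(hydroxymethyl)ethyl)pyrrolidin-2-yl)methyl gives a 2.3-fold lower number from compound 3 to compound 4 (0.36 log units; beyond the scatter). With that oxiranylmethyl group fixed, phenyl in place of 4-(tert-butyl)benzyl on the oxygen gives a 1.6-fold higher number from compound 2 to compound 4 (0.20 log units; within the scatter), whereas phenoxy in place of benzamido gives a 3.0-fold higher number from compound 1 to compound 4 (0.47 log units; beyond the scatter), so only the latter exchange on the aromatic carbon separates from the scatter. No measured data on these compounds offer an explanation for these steps.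

The nitrogen step rests on a single pair in which the oxirane ring, the hydroxymethyl arms and the ring attachment all change at once. A 1-methylpyrrolidin-3-yl group or a 1-(2,3-dihydroxypropyl)pyrrolidin-3-yl group on the same nitrogen would help show which of these parts carries the step.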